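This account rests on a few compounds, and the source may have more. Where it says the series, first, only, none or still open, it means among the compounds named here.

Working notes, series read in a functional assay on HeLa cells (Homo sapiens) for cytotoxicity, read by MTT assay, with a stated time of 48 h; a lower number here means a stronger inhibitor, a higher number a weaker inhibitor:

- compound 1 `Cc1nc2c3ccccc3ccc2c2nc3c(ccc4ccccc43)c(-c3cccnc3)c12`: 3860 nM
- compound 2 `COc1ccc(-c2c3ccc4ccccc4c3nc3c2c(C)nc2c4ccccc4ccc32)cc1`: 45900 nM
- compound 3 `Cc1nc2c3ccccc3ccc2c2nc3c(ccc4ccccc43)c(-c3cccc4ccccc34)c12`: 14900 nM

Compound 3 is second highest of the three numbers, at 14900 nM. It lies on either side of its neighbours by modest margins: a 3.9-fold higher number from compound 1 to compound 3 (0.59 log units; beyond the scatter) and a 3.1-fold lower number from compound 2 to compound 3 (0.49 log units; beyond the scatter).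

The next compound is compound 4 `Cc1ccc(-c2c3ccc4ccccc4c3nc3c2c(C)nc2c4ccccc4ccc32)cc1`, not yet measured. It has 4-methylphenyl in place of naphthalen-1-yl on an aromatic carbon, opposite the ring nitrogen (4-methylphenyl in place of naphthalen-1-yl on an aromatic carbon).

Going by the values given here, no measured step makes this exact exchange. The closest is the modest 3.1-fold lower number from compound 2 to compound 3 (0.49 log units; beyond the scatter), which exchanges 4-methoxyphenyl for naphthalen-1-yl at the same place. Among the compounds with values here, compound 2, the only measured compound with a 4-substituted phenyl group, gives 45900 nM, so compound 4 is expected to fall nearer that end of the series. The large 12-fold higher number from compound 1 to compound 2 (1.08 log units; beyond the scatter) shows that this place can shift the number considerably, which argues for a wide range. Within the data shown here, with only three compounds, this remains a thin basis.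

A modest step to a higher number is therefore expected in this assay. The expected step is a 2.1-fold higher number from compound 3 to compound 4 (0.33 log units; beyond the scatter). Compound 4 is estimated at 32000 nM. The estimated range for compound 4 runs from 12000 nM to 80000 nM.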

Compound 4, half-maximal inhibitory concentration: 72200 nM
Compound 4: middle estimate off by 2.3-fold (0.35 log units), on the low side; low and high end bracket the measured number.
By their numbers in this assay, from the lowest: compound 1; then compound 3; then compounds 2 and 4 (each within the scatter of the next).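

In this assay, going by these compounds alone, the step with methyl in place of methoxy on the phenyl ring is a 1.6-fold higher number from compound 2 to compound 4 (0.20 log units; within the scatter) and gives the first direct comparison of two 4-substituted phenyl groups at this aromatic carbon opposite the ring nitrogen, which compound 2 alone could not provide. Both of these compounds stand apart from the other two groups, with a 4.8-fold higher number from compound 3 to compound 4 (0.69 log units; beyond the scatter) and a 19-fold higher number from compound 1 to compound 4 (1.27 log units; beyond the scatter) as the steps from naphthalen-1-yl and pyridin-3-yl, so within these four compounds the change from either of those groups to 4-methylphenyl carries a real cost, largest from pyridin-3-yl, and compound 1 holds the lowest number. The compounds shown carry no measurement that explains these differences.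

Open, on these data alone, is whether the lower number of compound 1 depends on the ring nitrogen of pyridin-3-yl or would also appear with unsubstituted phenyl, since every carbocyclic group here gives a higher number. Equally open, as far as these compounds go, is what a 4-aminophenyl or 4-carboxyphenyl group would do at this carbon, since methyl and methoxy are the only substituents compared on the phenyl ring.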